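Chain extension on the imine of compound 2

This account rests on a few compounds, and the source may have more. Where it says the series, first, only, none or still open, it means among the compounds named here.

Compound 1 `N#CC1=C(NC(=O)c2ccc([N+](=O)[O-])cc2)N(c2ccc(S(N)(=O)=O)cc2)C2=C(C(=O)CCC2)C1c1ccc(Cl)cc1Cl` and compound 2 `CN(C)c1ccc(/C=N/C2=C(C#N)C(c3ccc(Cl)cc3Cl)C3=C(CCCC3=O)N2c2ccc(S(N)(=O)=O)cc2)cc1` share one core and have been tested in a functional assay on Ehrlich cells (Mus musculus) for cytotoxicity, read by trypan blue exclusion, with a stated time of 2 h, tested at 10 ug/mL; on this read-out lower numbers stand for a weaker effect and higher numbers for a stronger effect at the one concentration tested. In this assay compound 1 gives 40%, and compound 2 gives 10%, the lowest of the two numbers; the step of a number 30 percentage points lower from compound 1 to compound 2 (beyond the scatter) is beyond the scatter. Compound 3 `CN(C)c1ccc(/C=C/C=N/C2=C(C#N)C(c3ccc(Cl)cc3Cl)C3=C(CCCC3=O)N2c2ccc(S(N)(=O)=O)cc2)cc1` differs from compound 2 by 2-(4-(dimethylamino)phenyl)ethenyl in place of 4-(dimethylamino)phenyl on a carbon with a double bond to nitrogen. For the measured compounds named here, the one measured step exchanges a whole group on a double-bonded ring carbon and does not bear closely on this chain extension, so for compound 3 no step beyond the scatter is expected in this assay; the expected change is a number 5 percentage points higher from compound 2 to compound 3 (within the scatter). The estimate for compound 3 is 15%, with a range from 5% to 35%.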

Compound 3, a percentage reported as activity, at one concentration (the size of the read-out at that concentration, not a potency): 10%
For compound 3 the middle estimate is 5 percentage points above the measured one; measured number inside the range.
By their numbers in this assay, from the lowest: compounds 2 and 3 (each within the scatter of the next); then compound 1.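

On a carbon with a double bond to nitrogen, 2-(4-(dimethylamino)phenyl)ethenyl in place of 4-(dimethylamino)phenyl gives no change at the digits printed from compound 2 to compound 3 (within the scatter) in this assay at the one concentration tested. Unlike the earlier exchange of a whole group, this step changes only the chain, and the read-out does not move with it. No measurement at hand offers an explanation for this result. Still open, from the compounds shown here alone, is whether a carboxylic acid or a morpholine in place of the dimethylamino group would shift the number. Going by these compounds, a longer chain than ethenyl at this carbon also remains open.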